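A few compounds are considered here, and "the series" means these few. Any claim that something is new, unique, unknown or untested is made for them only; others in the source may bear on it.

Compound 2, `CC(C)S(=O)(=O)CCC12CCC(c3nnc(-c4ccccc4C(F)(F)F)n3C)(CC1)CC2`, carries a sulfur-containing chain on the shared core. Among the compounds with values here, in a functional assay on the whole organism (strain ICR) for inhibition, with Mus musculus as the target, with a stated time of 4 h, at a dose of 10 mg/kg by the oral route (a lower number here means less inhibition, a higher number more inhibition at the dose given (going by the name of the read-out)), compound 2 gives 88%, the higher of the two numbers measured so far. Its closest relative is compound 1, `Cn1c(-c2ccccc2C(F)(F)F)nnc1C12CCC(CNS(C)(=O)=O)(CC1)CC2`, which in this assay gives 73%. Within the data shown here, the one measured step between them, a number 15 percentage points higher from compound 1 to compound 2 (beyond the scatter), shows that exchanging one sulfur-bearing chain for another at this part of the molecule can move the read-out by a modest amount.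

Compound 3, `CC(O)CCCC12CCC(c3nnc(-c4ccccc4C(F)(F)F)n3C)(CC1)CC2`, changes the same chain again: 2-hydroxypropyl in place of isopropylsulfonyl on a saturated chain carbon, two bonds along the chain from a saturated ring carbon. Here the sulfur atom leaves altogether and a hydroxyl group enters, so the chain gains a hydrogen-bond donor while losing an acceptor. Among the measured compounds shown here, no measured step in this set covers a change of that kind; the step from compound 1 to compound 2 only shows that the chain matters, not which way this particular swap will go. The expectation for compound 3 is therefore a modest downward step, a number 18 percentage points lower from compound 2 to compound 3 (beyond the scatter), with wide uncertainty. Compound 3 is estimated at 70%, with a plausible range from 45% to 90%.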

Compound 3, a percentage reported as inhibition, in the whole organism at one dose (the size of the read-out at that dose, not a potency): 97%
Compound 3: middle estimate off by 27 percentage points, on the low side; the whole stated range lies below it.
By their numbers in this assay, from the lowest: compound 1; then compounds 2 and 3 (each within the scatter of the next).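

In this assay the sulfur-containing group turns out not to be needed at this position: a number 9 percentage points higher from compound 2 to compound 3 (within the scatter), with 2-hydroxypropyl in place of isopropylsulfonyl on a saturated chain carbon, two bonds along the chain from a saturated ring carbon. Seen from the other sulfur-bearing chain, there is a number 24 percentage points higher from compound 1 to compound 3 (beyond the scatter), with 3-hydroxybutyl in place of methanesulfonamido, so among these three compounds the chain without sulfur stands clear of the methanesulfonamido chain but not of the isopropylsulfonyl chain. No measurement offered here explains why these chains give the numbers they do.

Still open, going by these compounds, is whether the hydroxyl group itself contributes anything, which a plain pentyl chain carrying only carbon and hydrogen could test, while an amine or a carboxylic acid at the same place would show how far the chain end can be changed. The read-out is also taken at a single dose, so the closeness of compound 2 and compound 3 says nothing about how they would compare at lower doses.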